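A swap on an aromatic nitrogen of compound 2

A few compounds are considered here, and "the series" means these few. Any claim that something is new, unique, unknown or untested is made for them only; others in the source may bear on it.

Values so far in an ADME assay on HeLa cells (Homo sapiens) for cytotoxicity, read by MTT assay (a lower number here means a stronger inhibitor, a higher number a weaker inhibitor), are these:
- Compound 1 `COc1ccc(C[C@H]2COC(=O)[C@@H]2Cc2ccc(OCc3cn(-c4ccc(F)cc4)nn3)c(OC)c2)cc1OC` gives >= 600000 nM as a limit of the assay
- Compound 2 `COc1ccc(C[C@H]2COC(=O)[C@@H]2Cc2ccc(OCc3cn(-c4cccc(Cl)c4)nn3)c(OC)c2)cc1OC` gives 493000 nM as a true number

Among the measured compounds shown here, compound 2 at 493000 nM holds the only true number so far, so there is no range of measured values to place it in. The other result is the limit of >= 600000 nM in this assay, at which 1 of the 2 values shown sits, and belongs to compound 1, which means it marks a limit and not a number.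

Compound 3 `COc1ccc(-n2cc(COc3ccc(C[C@H]4C(=O)OC[C@@H]4Cc4ccc(OC)c(OC)c4)cc3OC)nn2)cc1` is still to be measured. It has 4-methoxyphenyl in place of 3-chlorophenyl on an aromatic nitrogen, and the counted change is 4-methoxyphenyl in place of 3-chlorophenyl on an aromatic nitrogen here.

For the measured compounds named here, one measured step bears on this, a swap on an aromatic nitrogen as well: an at least 1.2-fold lower number from compound 1 to compound 2 (0.08 log units; that floor lies within the scatter) in this comparison. That step shows no change beyond the scatter, so no step beyond the scatter is expected in this assay and neither direction is favoured. The expected step is a 1.0-fold higher number from compound 2 to compound 3 (0.01 log units; within the scatter) by this estimate. Compound 3 is estimated at 500000 nM with an expected range from 250000 nM to 800000 nM in this assay, and it may well be reported only as a limit.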

Compound 3, half-maximal inhibitory concentration: >= 600000 nM
Compound 3 ended at the assay's limit; the forecaster's own chance of this, stated with the estimate: 45%; at least 1.2-fold (0.07 log units) between middle value and limit.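

In this assay, the aromatic nitrogen now carries a third substituted phenyl group, and this swap gives no change beyond the scatter: an at least 1.2-fold higher number from compound 2 to compound 3 (0.08 log units; that floor lies within the scatter). So 4-methoxyphenyl, which counts one hydrogen-bond acceptor where 3-chlorophenyl counts none, does not separate compound 3 from compound 2 by more than repeated measurements would. The step between compound 1 and compound 3 cannot be read, and most of the series now rests on a limit rather than on a number: the limit of >= 600000 nM in this assay, at which 2 of the 3 values shown sit.

Among the compounds shown here, what stays open is whether an amine, a carboxylic acid or a longer alkyl chain on this nitrogen would give a number clearly lower than the one for compound 2, 493000 nM. On these data alone, it is also open whether a change elsewhere on the shared core would move the reading further than the swaps at this position have.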